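Hydroxamic acid cyclopropyl in place of the acid ether

The source may hold more compounds than are shown below. What is called first, only, known or untested is meant among the compounds shown, and "the series" means these compounds.

Two compounds of the series have numbers. In a functional assay on CHO cells for agonist activity at Free fatty acid receptor 1 (Homo sapiens), read by a luciferase reporter (a lower number here means a smaller maximal response, a higher number a larger maximal response), compound 1 `Cc1nc(-c2ccc(C(F)(F)F)cc2)sc1CNc1ccc(C(=O)O)cc1` gives 10% and compound 2 `CC(C)(Oc1ccc(NCc2cccc(Oc3ccccc3)c2)cc1)C(=O)O` gives 14%; the two values lie within the scatter of each other, so compound 2 does not stand apart from compound 1. Compound 3 `O=C(NO)[C@H]1C[C@@H]1c1ccc(NCc2cccc(Oc3ccccc3)c2)cc1` differs from compound 2 in one place: 2-(hydroxycarbamoyl)cyclopropyl in place of 1-carboxy-1-methylethoxy on an aromatic carbon. For the measured compounds named here, no measured pair isolates a change of this kind, so its direction is open. For compound 3 a response near the two known values is expected, with a number 2 percentage points lower from compound 2 to compound 3 (within the scatter) not beyond the scatter. For compound 3 the estimate is 12%, range 4% to 25%.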

Compound 3, largest response reached (reported as percent of maximum), in percent of the reference or control that the assay uses: 90%
Beside the measured number, compound 3's estimate is 78 percentage points below it, and the stated range ends below it.
By their numbers in this assay, from the lowest: compounds 1 and 2 (each within the scatter of the next); then compound 3.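

In this assay, 2-(hydroxycarbamoyl)cyclopropyl in place of 1-carboxy-1-methylethoxy on an aromatic carbon, para to a large group, gives a number 76 percentage points higher from compound 2 to compound 3 (beyond the scatter). This position therefore strongly governs the maximal response, and a large response in this series does not require the carboxy group of compound 2. Nothing at hand explains the size of this step.

Open, from the compounds shown here alone, is whether the cyclopropyl ring or the hydroxycarbamoyl carries the step. A carboxylic acid on the same cyclopropyl, or hydroxycarbamoyl on an ethylene chain, would separate the two.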